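A few compounds are considered here, and "the series" means these few. Any claim that something is new, unique, unknown or untested is made for them only; others in the source may bear on it.

Measured in a functional assay on HCT-116 cells (Homo sapiens) for antiproliferative activity, read by CCK-8 assay, with a stated time of 72 h; a higher number here means a weaker inhibitor, a lower number a stronger inhibitor:

- compound 1 `CCOc1cc(C(C)(C)C)ccc1C1=NC(c2ccc(Cl)cc2)C(c2ccc(Cl)cc2)N1C(=O)NCCCCCCCC(=O)NO` gives 5030 nM
- compound 2 `CCOc1cc(C(C)(C)C)ccc1C1=NC(c2ccc(Cl)cc2)C(c2ccc(Cl)cc2)N1C(=O)N1CCN(Cc2ccc(C(=O)NO)cc2)CC1` gives 2030 nM
- compound 3 `CCOc1cc(C(C)(C)C)ccc1C1=NC(c2ccc(Cl)cc2)C(c2ccc(Cl)cc2)N1C(=O)N1CCN(CCCCC(=O)NO)CC1` gives 5210 nM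

Compound 3 shares the high end of these numbers with compound 1, the two lying within the scatter of each other. Among the measured compounds shown here, the only measured step reaching it is a 2.6-fold higher number from compound 2 to compound 3 (0.41 log units; beyond the scatter), a modest one.

Compound 4 `CCOc1cc(C(C)(C)C)ccc1C1=NC(c2ccc(Cl)cc2)C(c2ccc(Cl)cc2)N1C(=O)N1CCN(CCCCCCCC(=O)NO)CC1` keeps the shared core and extends the chain of compound 3: 3-(hydroxycarbamoyl)propyl in place of hydroxycarbamoyl on a saturated chain carbon, four bonds along the chain from an amine nitrogen in a ring. Here 3-(hydroxycarbamoyl)propyl stands in place of hydroxycarbamoyl on a saturated chain carbon, four bonds along the chain from an amine nitrogen in a ring.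

The measured step bears on this only loosely, since it exchanged 4-(hydroxycarbamoyl)phenyl for 3-(hydroxycarbamoyl)propyl. For the measured compounds named here, no measured pair lengthens a chain alone. Compound 1 also carries a long chain ending in hydroxycarbamoyl and gives 5030 nM, which offers no sign of a large shift with length. A change no larger than that modest step is therefore expected in this assay, most likely within the scatter, with a slight lean toward a lower number. The expected change is a 1.4-fold lower number from compound 3 to compound 4 (0.14 log units; within the scatter). For compound 4 the estimated value is 3800 nM, with an expected range of 1500 nM to 9000 nM.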

Compound 4, half-maximal inhibitory concentration: 1710 nM
Estimate against measurement, compound 4: 2.2-fold (0.35 log units) above; the measured number falls inside the stated range.
By their numbers in this assay, from the lowest: compounds 4 and 2 (each within the scatter of the next); then compounds 1 and 3 (each within the scatter of the next).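

Measured in this assay the lengthening of the chain, with 3-(hydroxycarbamoyl)propyl in place of hydroxycarbamoyl four bonds along the chain from an amine nitrogen in a ring, gives a 3.0-fold lower number from compound 3 to compound 4 (0.48 log units; beyond the scatter) and is the one pair shown in which chain length alone changes, so length at this position does move the read-out. The comparison with the phenyl-containing linker also turns out to depend on length: the earlier step from compound 2 to compound 3 favoured the 4-(hydroxycarbamoyl)phenyl group over a shorter saturated chain, whereas 6-(hydroxycarbamoyl)hexyl in its place gives a 1.2-fold lower number from compound 2 to compound 4 (0.07 log units; within the scatter) and so reads alike. Nothing available accounts for the effect of chain length on this read-out.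

The compounds shown on this ring nitrogen cover only two saturated chain lengths, so it remains open whether a longer chain or one of intermediate length would give a lower or a higher number. As far as these compounds go, it also remains open how the longer chain would read with a carboxylic acid in place of the terminal hydroxycarbamoyl group.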